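The source may hold more compounds than are shown below. What is called first, only, known or untested is meant among the compounds shown, and "the series" means these compounds.

Measured compounds:
compound 1, `COc1cc(-c2ccnc3cc(-c4ccc(Cl)cc4)nn23)cc(OC)c1OC`, 3340 nM
compound 2, `COc1cc(-c2ccnc3cc(-c4ccccc4)nn23)cc(OC)c1OC`, 3880 nM
compound 3, `COc1ccc(-c2cc3nccc(-c4cc(OC)c(OC)c(OC)c4)n3n2)cc1`, 404 nM

All three were tested in a functional assay on HCT-116 cells (Homo sapiens) for inhibition, read by CCK-8 assay, with a stated time of 48 h; on this read-out lower numbers stand for stronger inhibition and higher numbers for weaker inhibition. Compound 3 gives the lowest number of the three; its nearest neighbour is compound 1, with an 8.3-fold lower number from compound 1 to compound 3 (0.92 log units; beyond the scatter), and compound 2 lies further, with a 9.6-fold lower number from compound 2 to compound 3 (0.98 log units; beyond the scatter). The step from compound 1 to compound 2 is a 1.2-fold higher number from compound 1 to compound 2 (0.07 log units; within the scatter).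

Compound 4, `CCOC(=O)c1ccc(-c2cc3nccc(-c4cc(OC)c(OC)c(OC)c4)n3n2)cc1`, is not yet measured. It differs from compound 3 in one place: ethoxycarbonyl in place of methoxy on an aromatic carbon.

The two steps that bear on this change are the ones into compound 3, where replacing chloro or hydrogen with methoxy at this same aromatic carbon gave a clearly lower number. For the measured compounds named here, none of the measured compounds carries ethoxycarbonyl here, so the direction is not settled by the data. Since both of the other groups tried at this place gave higher numbers than methoxy, compound 4 is expected to give a higher number than compound 3, a step of about a 3.7-fold higher number from compound 3 to compound 4 (0.57 log units; beyond the scatter), with wide uncertainty. The estimate for compound 4 is 1500 nM, ranging from 300 nM to 7000 nM.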

Compound 4, half-maximal inhibitory concentration: > 10000 nM
Compound 4 gave a limit, no number (the forecaster's own chance of this, stated with the estimate: 5%); at least 6.6-fold (0.82 log units) between middle value and limit.
By their numbers in this assay, from the lowest: compound 3; then compounds 1 and 2 (each within the scatter of the next). At a limit, above all of these: compound 4.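

In this assay compound 4 gives a limit and not a number: the limit of > 10000 nM in this assay, at which 1 of the 4 values shown sits. The earlier compounds shown here showed only that methoxy at this aromatic carbon gave a lower number than chloro or hydrogen, but swapping methoxy for ethoxycarbonyl gave an at least 24-fold higher number from compound 3 to compound 4 (1.39 log units; beyond the scatter), so carrying oxygen at this place does not by itself keep the number low. The new group also compares poorly with the simpler ones, with an at least 2.5-fold higher number from compound 2 to compound 4 (0.41 log units; beyond the scatter) and an at least 2.9-fold higher number from compound 1 to compound 4 (0.47 log units; beyond the scatter), so relative to plain hydrogen, a group at this place can move the number in either direction.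

From the compounds shown here alone, what remains open is whether the loss follows from the carbonyl or from the ethyl end of the ester. An ethoxy group, a carboxylic acid or an amide at this place would help separate the two.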